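Allyl Carbamate Selenocyanate: Expectation From Three Alkyl Analogues

This account rests on a few compounds, and the source may have more. Where it says the series, first, only, none or still open, it means among the compounds named here.

Three carbamates built on a shared core were tested in a functional assay on HT-29 cells (Homo sapiens) for cytotoxicity, read by MTT assay, with a stated time of 72 h; on this read-out lower numbers stand for higher toxicity in this test and higher numbers for lower toxicity in this test. Compound 1 `CCCOC(=O)Nc1ccc([Se]C#N)cc1` gives 75400 nM. Compound 2 `CCCCOC(=O)Nc1ccc([Se]C#N)cc1` gives 63700 nM, and compound 3 `CC(C)COC(=O)Nc1ccc([Se]C#N)cc1` gives 63700 nM. The steps among them are small: a 1.2-fold lower number from compound 1 to compound 2 (0.07 log units; within the scatter), a 1.2-fold lower number from compound 1 to compound 3 (0.07 log units; within the scatter), and no change at the digits printed from compound 2 to compound 3 (within the scatter). Compound 3 thus stands level with compound 2 at the digits shown, the two together holding the lowest numbers of the three, with compound 1 separated from them only by a margin within the scatter.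

Compound 4 `C=CCOC(=O)Nc1ccc([Se]C#N)cc1` has not yet been measured. It differs from compound 3 by vinyl in place of isopropyl on a saturated chain carbon bound to an oxygen next to a carbonyl group; cut one bond further out, the same change reads isobutyl to allyl, or isobutoxy to allyloxy. The step that bears most directly on it is the exchange at the same place, no change at the digits printed from compound 2 to compound 3 (within the scatter), which left the number untouched; the two methyl additions, a 1.2-fold lower number from compound 1 to compound 2 (0.07 log units; within the scatter) and a 1.2-fold lower number from compound 1 to compound 3 (0.07 log units; within the scatter), were likewise within the scatter. Among these three compounds the group at that place has not shifted the number beyond the scatter, so a step of at most that size, in no fixed direction, is expected here as well, a 1.0-fold higher number from compound 3 to compound 4 (0.01 log units; within the scatter). Compound 4 is accordingly estimated at 65000 nM, with a range from 30000 nM to 140000 nM.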

Compound 4, concentration lethal to 50% of the cells: 72800 nM
Beside the measured number, compound 4's estimate is 1.1-fold (0.05 log units) below it, within the range that was stated.
By their numbers in this assay, from the lowest: compounds 2, 3, 4 and 1 (each within the scatter of the next).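

In this assay, among the compounds shown here, the earlier compounds carried only saturated groups on the saturated chain carbon bound to an oxygen next to a carbonyl group, whereas vinyl brings a double bond outside aromatic rings to that place, with fewer heavy atoms than the isopropyl it replaces. The reading stays within the scatter against all three neighbours, a 1.1-fold higher number from compound 3 to compound 4 (0.06 log units; within the scatter), a 1.1-fold higher number from compound 2 to compound 4 (0.06 log units; within the scatter) and a 1.0-fold lower number from compound 1 to compound 4 (0.02 log units; within the scatter), so in this series neither the double bond nor the loss of the branch separates compound 4 from the saturated carbamates. Nothing measured here offers an explanation for this flat reading.

From the compounds shown here alone, all four compounds sit within the scatter of one another, so it remains open whether any group at this place can move the number beyond it, such as a phenyl ring, a longer chain like octyl, or a chain ending in an amine or a carboxylic acid. The selenocyanate and the carbamate link are common to all four, which leaves open whether a thiocyanate or an amide in their stead would shift the number in this assay.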